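The source may hold more compounds than are shown below. What is called first, only, known or untested is meant among the compounds shown, and "the series" means these compounds.

In a physicochemical assay for permeability, using PAMPA, with a stated time of 4 h, at pH 7.4, tested at 50 uM (a lower number here means that the compound crosses the layer more slowly, a higher number that the compound crosses the layer faster), compound 2 `Cc1c(Cl)cccc1CCCCOc1ccc(C#Cc2cccc3c(CCCC(=O)O)c(C)n(CCCCC(=O)O)c23)cc1` gives 5 10^-6 cm/s. For the measured compounds named here, only one other compound has been measured: compound 1 `Cc1c(Cl)cccc1CCCCOc1ccc(C#Cc2cccc3c(CCCC(=O)O)c(C)n(CCC(=O)O)c23)cc1`, which in this assay gives 3 10^-6 cm/s, and the step of a 1.7-fold higher number from compound 1 to compound 2 (0.22 log units; within the scatter) leaves the two within the scatter of each other, so neither stands apart from the other. Compound 3 `Cc1c(Cl)cccc1CCCCOc1ccc(C#Cc2cccc3c(CC(=O)O)c(C)n(CCCCC(=O)O)c23)cc1` is the next to be measured; it differs from compound 2 by carboxy in place of 2-carboxyethyl on a saturated chain carbon bound to an aromatic carbon. Going by the values given here, the single measured step bears on this directly: from compound 1 to compound 2 the same two groups were exchanged in the opposite sense, a 2-carboxyethyl replacing a carboxy on a saturated chain carbon two bonds along the chain from an aromatic nitrogen, and that exchange moved the number only within the scatter. Shortening this second acid chain is therefore expected to change little: compound 3 is estimated at 4 10^-6 cm/s, between 2 10^-6 cm/s and 8 10^-6 cm/s, which means an expected step of a 1.3-fold lower number from compound 2 to compound 3 (0.10 log units; within the scatter).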

Compound 3, apparent permeability: 1 10^-6 cm/s
Compound 3: middle estimate off by 4.0-fold (0.60 log units), on the high side; the measured number lies below the stated range.
By their numbers in this assay, from the lowest: compound 3; then compounds 1 and 2 (each within the scatter of the next).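

In this assay, this place proves more sensitive than the measured step at the other acid chain suggested: carboxy in place of 2-carboxyethyl on a saturated chain carbon bound to an aromatic carbon gives a 5.0-fold lower number from compound 2 to compound 3 (0.70 log units; beyond the scatter), beyond the scatter, whereas the earlier exchange of the same two groups, two bonds along the chain from an aromatic nitrogen, gave a 1.7-fold higher number from compound 1 to compound 2 (0.22 log units; within the scatter). The same exchange therefore does not carry the same size of step at both places, and a result from one chain cannot simply be applied to the other. Nothing available explains this difference, so its cause remains unknown.

Going by these compounds, it remains open whether the step would keep its size with the shorter acid chain of compound 1 on the nitrogen. On these data alone, it is also open how a methyl ester or an amide in place of the carboxy group at this place would read.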